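The source may hold more compounds than are shown below. What is called first, only, known or untested is meant among the compounds shown, and "the series" means these compounds.

Compound 1 `O=C(Nc1ccc(O)cc1)c1c(NO)cc(-c2ccccc2)oc1=O` is one of two related molecules tested in an ADME assay on Huh-7 cells (Homo sapiens) for cytotoxicity, read by a luciferase reporter and WST assay, with a stated time of 3 days; a lower number here means that less compound is tolerated, a higher number that more compound is tolerated. Its result is a limit of the assay rather than a number: compound 1 gives > 20000 nM. The second molecule, compound 2 `Cc1ccc(NC(=O)c2c(NO)cc(-c3ccc(Cl)cc3)oc2=O)cc1`, likewise reaches only a limit, giving > 20000 nM. So compound 1 stands at the ceiling of what was measured, which is the limit of > 20000 nM in this assay, at which 2 of the 2 values shown sit. A third molecule, compound 3 `O=C(NCCO)c1c(NO)cc(-c2ccccc2)oc1=O`, has not yet been tested in this assay. It differs from compound 1 in one place: 2-hydroxyethyl in place of 4-hydroxyphenyl on an amide-type nitrogen. For the measured compounds named here, no measured pair in this set shows what such a change does to the tolerated concentration, so the expectation rests on the ceiling alone. Because the two measured values sit at the limit of > 20000 nM in this assay, at which 2 of the 2 values shown sit, the step expected here is a step that the limit leaves unreadable from compound 1 to compound 3, within the scatter. Compound 3 is therefore estimated at 25000 nM, with a range from 15000 nM to 60000 nM, and a limit is again the likeliest outcome.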

Compound 3, half-maximal cytotoxic concentration: > 20000 nM
Compound 3: a limit, no number; the forecaster's own chance of this, stated with the estimate: 85%; the middle value does not contradict the limit.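

No step can be read from compound 1 to compound 3, because each result in this assay is only a limit: the limit of > 20000 nM in this assay, at which 3 of the 3 values shown sit.

The compounds shown leave open whether putting 2-hydroxyethyl in place of 4-hydroxyphenyl changes the tolerated concentration at all, and where any of the three would begin to harm the cells.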